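Amide substituent series: from compound 3 to compound 4

The source may report more compounds than this note shows. Statements on the series, on what has been measured and on what is new or still open speak of the compounds shown alone.

Measured so far in a functional assay on BXPC-3 cells (Homo sapiens) for antiproliferative activity, read by MTT assay, with a stated time of 24 h; on this read-out higher numbers stand for weaker inhibition and lower numbers for stronger inhibition:
- compound 1 `CCn1c(C(=O)N[C@@H](C)C(=O)OC)ccc1C(CC)(CC)c1ccc(OCS(=O)(=O)c2ccccc2)c(C)c1` gives 17900 nM
- compound 2 `CCn1c(C(=O)NCC(=O)OC)ccc1C(CC)(CC)c1ccc(OCS(=O)(=O)c2ccccc2)c(C)c1` gives 20000 nM
- compound 3 `CCn1c(C(=O)N[C@H](CO)CCO)ccc1C(CC)(CC)c1ccc(OCS(=O)(=O)c2ccccc2)c(C)c1` gives 15900 nM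

Compound 3, at 15900 nM, stands within the scatter of both other compounds, so the three numbers cannot be ranked. Compound 4 `CCn1c(C(=O)N[C@H](CO)CCCO)ccc1C(CC)(CC)c1ccc(OCS(=O)(=O)c2ccccc2)c(C)c1` is the next to be measured in this assay. The change is hydroxymethyl in place of hydroxy on a saturated chain carbon, three bonds along the chain from an amide-type nitrogen. In words, hydroxymethyl takes the place of hydroxy on a saturated chain carbon, three bonds along the chain from an amide-type nitrogen. The same difference reads as 2-hydroxyethyl to 3-hydroxypropyl when cut further out.

Among the compounds with values here, no measured step makes this exact change. The nearest evidence comes from exchanges on the same amide-type nitrogen: a 1.1-fold lower number from compound 1 to compound 3 (0.05 log units; within the scatter) and a 1.3-fold lower number from compound 2 to compound 3 (0.10 log units; within the scatter). The remaining step, a 1.1-fold higher number from compound 1 to compound 2 (0.05 log units; within the scatter), removes a methyl from the chain carbon bound to that nitrogen. All three steps lie within the scatter, so these three compounds show no sensitivity to the substituent on that nitrogen. The smaller change to compound 4 is therefore expected to produce no step beyond the scatter. The estimated step is a 1.0-fold higher number from compound 3 to compound 4 (0.00 log units; within the scatter). For compound 4 the expected value is 16000 nM, with an estimated range of 9500 nM to 26000 nM.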

Compound 4, half-maximal inhibitory concentration: > 50000 nM
Compound 4: a limit, no number; the forecaster's own chance of this, stated with the estimate: 5%; middle value at least 3.1-fold (0.49 log units) from the limit.
By their numbers in this assay, from the lowest: compounds 3, 1 and 2 (each within the scatter of the next). At a limit, above all of these: compound 4.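

In this assay, the entry for compound 4 is a limit, not a number: the limit of > 50000 nM in this assay, at which 1 of the 4 values shown sits. Going from 2-hydroxyethyl to 3-hydroxypropyl on the amide-type nitrogen's chain gives (an at least 3.1-fold higher number from compound 3 to compound 4 (0.49 log units; beyond the scatter)), so this position responds to a small change, although the earlier exchanges on that nitrogen all stayed within the scatter. The two wider exchanges on the same nitrogen, (an at least 2.5-fold higher number from compound 2 to compound 4 (0.39 log units; beyond the scatter)) and (an at least 2.7-fold higher number from compound 1 to compound 4 (0.44 log units; beyond the scatter)), also lie beyond the scatter, which sets compound 4 apart from all three earlier compounds and shows that the substituent on this nitrogen can matter in this assay.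

The compounds shown leave open how large the loss is, and whether it follows the length of the chain or the placing of the terminal hydroxy. A 4-hydroxybutyl chain, or a 3-aminopropyl or carboxylic acid terminus on the same chain, would show whether the loss continues with a longer chain and whether the terminal hydroxy itself plays any part.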